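Chromenone thioethers: adding a methyl group to compound 3

This account rests on a few compounds, and the source may have more. Where it says the series, first, only, none or still open, it means among the compounds named here.

Of the compounds shown here, three have been measured in a functional assay on KBVIN cells (Homo sapiens) for antiproliferative activity, read by sulforhodamine B assay, with a stated time of 72 h; a lower number here means a stronger inhibitor of growth, a higher number a weaker inhibitor of growth. Compound 1, `Cc1cc(=O)oc2cc(SCc3cccc(C#N)c3)ccc12`, gives only a limit, > 32500 nM. Compound 2, `Cc1cc(=O)oc2cc(SCc3cccc(OC(F)(F)F)c3)ccc12`, gives 15300 nM. Among the measured compounds shown here, the one single-point step among them, an at least 2.1-fold lower number from compound 1 to compound 2 (0.32 log units; beyond the scatter), concerns a group on a distant ring. Compound 3, `CCc1cc(=O)c2ccc(Sc3cccc(Cl)n3)cc2o1`, again gives only a limit, > 31400 nM, and so stands at the limit of > 31400 nM in this assay, at which 1 of the 3 values shown sits, the weak end of what was measured.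

Compound 4, `CCc1cc(=O)c2ccc(Sc3cccc(Cl)n3)c(C)c2o1`, differs from compound 3 in one place: methyl in place of hydrogen on an aromatic carbon. For the measured compounds named here, no measured step concerns a methyl for hydrogen exchange, and the trifluoromethoxy for cyano step was made on a different ring, so it gives no direct guide here. Compound 4 is therefore expected to behave much like compound 3, with a step that the limit leaves unreadable from compound 3 to compound 4 in this assay not beyond the scatter, and most likely again only a limit. Compound 4 is estimated at 35000 nM, within a range from 8000 nM to 120000 nM.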

Compound 4, concentration for 50% growth inhibition: 23900 nM
Estimate against measurement, compound 4: 1.5-fold (0.17 log units) above; measured number inside the range.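

In this assay, methyl in place of hydrogen on an aromatic carbon, ortho to a fused ring, gives an at least 1.3-fold lower number from compound 3 to compound 4 (0.11 log units; that floor lies within the scatter). This is the first step shown at this position, and it shows that the added methyl still leaves compound 4 with a true measured value rather than a limit. The real size of the step stays unknown because compound 3 gives only a limit, so the step has a floor and no fixed value: the limit of > 31400 nM in this assay, at which 1 of the 4 values shown sits.

The compounds shown leave open whether the methyl brings a change beyond the scatter, and whether the same exchange would act alike on the core of compound 1 or compound 2. They also leave open what an amine, a carboxylic acid or a longer chain on this same carbon would do in this assay.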